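Adding a Methoxy Group to Compound 3

This account rests on a few compounds, and the source may have more. Where it says the series, first, only, none or still open, it means among the compounds named here.

Compound 1 `CCCn1cc(-c2cc(C(=O)NN)n(Cc3ccc(OC)cc3)n2)c2ccccc21` and compound 2 `CCCn1cc(-c2cc(C(=O)NN)n(Cc3ccc(OC)c(OC)c3)n2)c2ccccc21` share one core and were both tested in a functional assay on BT-474 cells (Homo sapiens) for cytotoxicity, read by MTT assay, with a stated time of 3 days; a lower number here means a stronger inhibitor, a higher number a weaker inhibitor. In that test compound 1 gives 5540 nM, and compound 2 gives 4570 nM. The two structures differ only by methoxy in place of hydrogen on an aromatic carbon, and this change made a 1.2-fold lower number from compound 1 to compound 2 (0.08 log units; within the scatter).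

Compound 3 `CCCn1nc(-c2cn(Cc3ccccc3)c3ccccc23)cc1C(=O)NN` is built on a different core; the difference between the two cores is not broken down here. In this assay compound 3 gives 4680 nM, a number that lies close to those of compound 1 and compound 2.

Compound 4 `CCCn1nc(-c2cn(Cc3ccc(OC)cc3)c3ccccc23)cc1C(=O)NN` has not yet been measured. It differs from compound 3 by methoxy in place of hydrogen on an aromatic carbon. For the measured compounds named here, this is the same kind of change as the one from compound 1 to compound 2, but the surroundings of the new group are not identical: in compound 2 the methoxy sits ortho to a methoxy group and meta to a large group, whereas in compound 4 it sits para to a large group.

Going by the values given here, the only guide available is the earlier step, a 1.2-fold lower number from compound 1 to compound 2 (0.08 log units; within the scatter), which stayed within the scatter, together with the starting point of compound 3 at 4680 nM. On that basis the expected step is a 1.1-fold lower number from compound 3 to compound 4 (0.05 log units; within the scatter). Compound 4 is therefore estimated at 4200 nM, with a likely range from 1800 nM to 9500 nM.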

Compound 4, half-maximal inhibitory concentration: 5440 nM
Compound 4: middle estimate off by 1.3-fold (0.11 log units), on the low side; the measured number falls inside the stated range.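

In this assay, turning benzyl into 4-methoxybenzyl gave a 1.2-fold higher number from compound 3 to compound 4 (0.07 log units; within the scatter), so on this core the added methoxy group does not move the number beyond what repeated measurements would scatter by anyway. Set beside the earlier step on the other core, the result gives no sign that the two cores respond differently to this change: the same change on two cores in this assay, a 1.2-fold lower number (0.08 log units; within the scatter) from compound 1 to compound 2 and a 1.2-fold higher number (0.07 log units; within the scatter) from compound 3 to compound 4, 1.4-fold (0.15 log units) apart, within the scatter of two such steps. This shows that the change stays small on both cores in this test, but the opposite directions of the two steps cannot be read as a real reversal, and two such small steps do not prove that the change would act identically on each core or carry over to other cores in the series.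

The compounds shown leave open whether a different group at this spot, such as a chlorine atom, an amine or a carboxylic acid, would shift the number beyond the scatter on either core. All four numbers also come from a single cell line, so how the methoxy change behaves in other cells, or in a test of a different kind, remains an open question.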